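The compounds below may be only part of what the source reports. "The series", "measured", "known", "first", "only" and "open" are said of these compounds alone.

In a functional assay on the whole organism for inhibition, with Rattus norvegicus as the target (on this read-out higher numbers stand for an effect only at larger amounts of compound and lower numbers for an effect already at smaller amounts), compound 3 (`CC1CC/C(=N\Nc2ccc(Br)cc2)c2ncc(C(=O)O)c(=O)n21`) gives > 1000 umol/kg, which is a limit of the assay rather than a number. Compound 1 (`CC1CC/C(=N\Nc2ccccc2Cl)c2ncc(C(=O)O)c(=O)n21`) gives > 1000 umol/kg in this assay, also a limit. Compound 2 (`CC1CC/C(=N\Nc2ccccc2Br)c2ncc(C(=O)O)c(=O)n21`) gives > 320 umol/kg in this assay, again a limit. Among the measured compounds shown here, compound 3 thus sits at the limit of > 1000 umol/kg in this assay, at which 2 of the 3 values shown sit, and the only value that stands elsewhere, (the limit of > 320 umol/kg in this assay, at which 1 of the 3 values shown sits), is a limit as well. The steps among these three compounds, a step that the two limits leave unreadable from compound 1 to compound 2, a step that the two limits leave unreadable from compound 1 to compound 3 and a step that the two limits leave unreadable from compound 2 to compound 3, therefore show no readable size in either direction, since every value involved is a limit.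

Compound 4 (`COc1ccccc1N/N=C1\CCC(C)n2c1ncc(C(=O)O)c2=O`) has not yet been measured in this assay. It differs from compound 3 by 2-methoxyphenyl in place of 4-bromophenyl on an amine nitrogen. For the measured compounds named here, none of the measured steps involves a 2-methoxyphenyl group, and none of them has a readable size, so they give no ground for expecting a step beyond the scatter in either direction. Compound 4 is therefore expected to sit near the same limit as compound 3, an estimated step of a number no higher from compound 3 to compound 4 (the limit leaves the size open). The estimate for compound 4 in this assay is 1000 umol/kg, with a range from 300 umol/kg to 3000 umol/kg.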

Compound 4, dose for 50% inhibition: > 1000 umol/kg
Compound 4 ended at the assay's limit (the forecaster's own chance of this, stated with the estimate: 85%); the middle value sits exactly at the limit.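

In this assay compound 4 gives > 1000 umol/kg, which is a limit of the assay. Its steps from compound 1, compound 2 and compound 3 all join two limits, and none of them can be read. The compounds shown leave open whether changing the group on the amine nitrogen alters the dose needed in this assay at all.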